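Rearranging the Dimethoxyphenyl Group of Compound 3

This account rests on a few compounds, and the source may have more. Where it says the series, first, only, none or still open, it means among the compounds named here.

In a functional assay on MCF7 cells (Homo sapiens) for cytotoxicity, read by MTT assay, with a stated time of 72 h (on this read-out higher numbers stand for weaker inhibition and lower numbers for stronger inhibition), compound 1 `O=C1C(=Cc2ccc(F)cc2)C(=O)N(c2ccc(Cl)cc2)N1c1ccc(Cl)cc1` gives 31400 nM and compound 2 `O=C1C(=Cc2ccc(Cl)cc2)C(=O)N(c2ccc(Cl)cc2)N1c1ccc(Cl)cc1` gives 28500 nM, which is a 1.1-fold lower number from compound 1 to compound 2 (0.04 log units; within the scatter). Compound 3 `COc1ccc(C=C2C(=O)N(c3ccc(Cl)cc3)N(c3ccc(Cl)cc3)C2=O)cc1OC` has no exact number, only a limit of the assay, > 128000 nM. Putting 3,4-dimethoxyphenyl in place of the halogen-bearing group gives an at least 4.0-fold higher number from compound 1 to compound 3 (0.61 log units; beyond the scatter) and also an at least 4.4-fold higher number from compound 2 to compound 3 (0.65 log units; beyond the scatter).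

Compound 4 `COc1cccc(C=C2C(=O)N(c3ccc(Cl)cc3)N(c3ccc(Cl)cc3)C2=O)c1OC` has the same atoms as compound 3, joined differently, with 2,3-dimethoxyphenyl in place of 3,4-dimethoxyphenyl (2,3-dimethoxyphenyl in place of 3,4-dimethoxyphenyl on a double-bonded chain carbon bound to a double-bonded ring carbon). The two measured steps into compound 3 show what happens when a dimethoxyphenyl group replaces a halogen-bearing one, but neither shows what happens when the methoxy groups are rearranged. Compound 4 keeps both methoxy groups, so it is expected to stay close to compound 3 in this assay, with no step beyond the scatter. The expected change is an at least 1.1-fold lower number from compound 3 to compound 4 (0.06 log units; that floor lies within the scatter). For compound 4 the estimate is 110000 nM, with an expected range of 40000 nM to 180000 nM.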

Compound 4, half-maximal inhibitory concentration: 11900 nM
Estimate against measurement, compound 4: 9.2-fold (0.97 log units) above, outside the stated range (below it).
By their numbers in this assay, from the lowest: compound 4; then compounds 2 and 1 (each within the scatter of the next). At a limit, above all of these: compound 3.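

Rearranging the methoxy groups, with the atoms unchanged, matters at this position in this assay: 2,3-dimethoxyphenyl in place of 3,4-dimethoxyphenyl gives an at least 10-fold lower number from compound 3 to compound 4 (1.03 log units; beyond the scatter), so the arrangement of the groups counts, not merely their presence. Compound 3 stands only at a limit of the assay, which makes the size of that step a floor: the limit of > 128000 nM in this assay, at which 1 of the 4 values shown sits A dimethoxyphenyl group also does not always give the higher number, as the steps from the halogen-bearing compounds show: a 2.4-fold lower number from compound 2 to compound 4 (0.38 log units; beyond the scatter) and a 2.6-fold lower number from compound 1 to compound 4 (0.42 log units; beyond the scatter).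

Which of the two methoxy groups drives the difference remains open. So does whether a phenyl group carrying a single methoxy group, or a hydroxy group in place of one methoxy group, would hold the lower number.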